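The source may report more compounds than this note shows. Statements on the series, on what has been measured and on what is new or still open speak of the compounds shown alone.

Measured in a functional assay on CWR22R cells (Homo sapiens) for antiproliferative activity, read by propidium iodide staining, with a stated time of 96 h; on this read-out higher numbers stand for weaker inhibition and lower numbers for stronger inhibition:
- compound 1 `CC(O)(CS(=O)(=O)c1cccc(S(F)(F)(F)(F)F)c1)C(=O)Nc1cccc(S(F)(F)(F)(F)F)c1`: 15400 nM
- compound 2 `CC(O)(CS(=O)(=O)c1ccc(F)cc1)C(=O)Nc1cccc(S(F)(F)(F)(F)F)c1`: 38900 nM

Compound 2 has the higher number of the two at 38900 nM, which means the weaker inhibition. Compound 1 lies lower at 15400 nM, by a margin beyond the scatter.

Compound 3 `CC(O)(CS(=O)(=O)c1cccc(C(F)(F)F)c1)C(=O)Nc1cccc(S(F)(F)(F)(F)F)c1` has not yet been measured. It keeps the rest of compound 2 and carries 3-(trifluoromethyl)phenyl in place of 4-fluorophenyl on a sulfonyl sulfur.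

Among the measured compounds shown here, no measured pair differs in one place, so the size of this change in this assay cannot be read directly. A modest move towards a lower number is expected, near the edge of the scatter. For the measured compounds named here, this expectation rests only on compound 1 at 15400 nM, the one measured compound with a lower number than compound 2, and it is therefore weakly founded. The expected change is a 1.9-fold lower number from compound 2 to compound 3 (0.29 log units; within the scatter). Compound 3 is estimated at 20000 nM, with an expected range from 9000 nM to 42000 nM.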

Compound 3, half-maximal inhibitory concentration: 24600 nM
The estimate for compound 3 lay 1.2-fold (0.09 log units) below the measured number; measured number inside the range.
By their numbers in this assay, from the lowest: compounds 1, 3 and 2 (each within the scatter of the next, the first and the last beyond it).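

In this assay, the series now has its first readable single-place comparisons. With 3-(trifluoromethyl)phenyl in place of 4-fluorophenyl on a sulfonyl sulfur, the result is a 1.6-fold lower number from compound 2 to compound 3 (0.20 log units; within the scatter), so at this position the exchange of one fluorinated phenyl group for the other does not separate the two compounds beyond the scatter. The second comparison has a group of 4 heavy atoms (1 carbon, 3 fluorine; no ring) in place of a group of 6 heavy atoms (5 fluorine, 1 sulfur; no ring), on an aromatic carbon, and gives a 1.6-fold higher number from compound 1 to compound 3 (0.20 log units; within the scatter), which is also within the scatter, and no measurement at hand accounts for either step.

From the compounds shown here alone, whether an amine, a carboxylic acid or a nitrile on the phenyl ring at the sulfonyl sulfur would shift the number beyond the scatter remains open. Also open, going by these compounds, is how the series responds to changes elsewhere in the shared core, such as a methoxy group in place of the hydroxyl group or a substituent on the amide nitrogen.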